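This account rests on a few compounds, and the source may have more. Where it says the series, first, only, none or still open, it means among the compounds named here.

Measured compounds in an ADME assay (Canis lupus familiaris, strain Beagle) for pharmacokinetics; a lower number here means that more of the compound stays in the plasma, a higher number that more of the compound sits outside the plasma:

- compound 1, `CCn1c(-c2cnc(C)nc2)nc2c(O[C@H]3CCN(C(=O)C4CC4)C3)ncnc21`: 0.6 L/kg
- compound 2, `CCn1c(-c2cnc(C)nc2)nc2c(N[C@H]3CCN(C(=O)N4CC(OC)C4)C3)ncnc21`: 1.4 L/kg
- compound 3, `CCC(=O)N1CC[C@H](Nc2ncnc3c2nc(-c2cnc(C)nc2)n3CC)C1`: 1.5 L/kg

Compound 1 gives the lowest of the three numbers in this assay; compound 2 and compound 3 both sit beyond the scatter above it. Among the measured compounds shown here, compound 2 and compound 3 share the shared core with an amine link and differ only at the acyl group on the ring nitrogen; that step, a 1.1-fold higher number from compound 2 to compound 3 (0.03 log units; within the scatter), is within the scatter, so the one measured change at the acyl position leaves the number where it was.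

Compound 4, `CCn1c(-c2cnc(C)nc2)nc2c(O[C@H]3CCN(C(=O)C4CCOC4)C3)ncnc21`, keeps the ether link of compound 1 and alters only the acyl group: oxolan-3-yl in place of cyclopropyl on a carbonyl carbon. For the measured compounds named here, no measured pair shows this exact exchange. Going by the values given here, the nearest precedent is the acyl-group step in compound 2 and compound 3, which produced no shift beyond the scatter. On that basis the step of a 1.2-fold higher number from compound 1 to compound 4 (0.07 log units; within the scatter) is expected to be small, within the scatter, with no direction called. Compound 4 is therefore estimated at 0.7 L/kg, in the range 0.4 L/kg to 1.2 L/kg.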

Compound 4, volume of distribution: 0.7 L/kg
For compound 4 middle estimate and measured number coincide at the digits printed; the measured number falls inside the stated range.
By their numbers in this assay, from the lowest: compounds 1, 4, 2 and 3 (each within the scatter of the next, the first and the last beyond it).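

In this assay, among the compounds shown here, the reading a 1.2-fold higher number from compound 1 to compound 4 (0.07 log units; within the scatter) is the first for an acyl exchange on the ether-linked core, and it lies within the scatter with oxolan-3-yl, carrying its ring oxygen and hydrogen-bond acceptor, in place of cyclopropyl on a carbonyl carbon. With a 1.1-fold higher number from compound 2 to compound 3 (0.03 log units; within the scatter) on the amine-linked core, both single acyl exchanges shown stay within the scatter, and neither goes against the other, though two pairs with different groups make only a narrow pattern. No evidence on the reason for this result is available.

On these data alone, the separate contribution of the ether and amine links stays open, since compound 1 and compound 3 differ in both link and acyl group. An acyl group bearing a primary amine or a carboxylic acid, or a longer alkyl chain, on the carbonyl carbon could still move the number in this assay.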